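The compounds below may be only part of what the source reports. "The series", "measured", "known", "first", "only" and "open" are said of these compounds alone.

In a functional assay on MDA-MB-231 cells (Homo sapiens) for inhibition, read by MTT assay, with a stated time of 48 h (a higher number here means a weaker inhibitor of growth, a lower number a stronger inhibitor of growth), compound 1 (`Oc1ccc(NC(=S)Nc2ccc3ncnc(Nc4cccc(Br)c4)c3c2)cc1`) gives 17300 nM and compound 2 (`FC(F)(F)c1cc(NC(=S)Nc2ccc3ncnc(Nc4cccc(Br)c4)c3c2)ccc1Cl`) gives 1100 nM as the lower of the two numbers. Compound 3 (`FC(F)(F)c1cccc(NC(=S)Nc2ccc3ncnc(Nc4cccc(Br)c4)c3c2)c1`) keeps the trifluoromethyl group and loses the chloro: hydrogen in place of chloro on an aromatic carbon with hydrogen in place of chloro on an aromatic carbon, ortho to a trifluoromethyl group and para to a large group. For the measured compounds named here, the only measured step bearing on this is a 16-fold lower number from compound 1 to compound 2 (1.20 log units; beyond the scatter) with 4-chloro-3-(trifluoromethyl)phenyl in place of 4-hydroxyphenyl on an amide-type nitrogen. Going by the values given here, that large step exchanged more than the chloro, and no measured pair isolates the chloro alone. A much smaller move toward a higher number is therefore expected in this assay and it may not clear the scatter. The expected step is a 2.0-fold higher number from compound 2 to compound 3 (0.30 log units; within the scatter) by this estimate. For compound 3 the estimated value is 2200 nM with an expected range from 900 nM to 6000 nM in this assay.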

Compound 3, concentration for 50% growth inhibition: 1400 nM
Estimate against measurement, compound 3: 1.6-fold (0.20 log units) above, and the stated range covers the measured number.
By their numbers in this assay, from the lowest: compounds 2 and 3 (each within the scatter of the next); then compound 1.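

In this assay, hydrogen in place of chloro on the aromatic carbon ortho to the trifluoromethyl group and para to a large group gives a 1.3-fold higher number from compound 2 to compound 3 (0.10 log units; within the scatter), so the chloro makes no difference here that clears the scatter. The 3-(trifluoromethyl)phenyl group also gives a 12-fold lower number from compound 1 to compound 3 (1.09 log units; beyond the scatter), which shows that the large step away from 4-hydroxyphenyl does not depend on the chloro. Nothing available speaks to a cause for either step.

That large step changes the phenyl group in two places, so the share of the lost hydroxyl and the share of the trifluoromethyl group cannot be separated. On these data alone, it also remains open whether an amine or a methoxy group at the chloro position would read differently from hydrogen, and whether a nitrile could stand in for the trifluoromethyl group.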